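The source may hold more compounds than are shown below. What is called first, only, known or untested is meant among the compounds shown, and "the series" means these compounds.

Measured so far in an ADME assay on NIH3T3 cells (Mus musculus) for cytotoxicity, read by MTT assay, with a stated time of 24 h; on this read-out higher numbers stand for weaker inhibition and lower numbers for stronger inhibition:

- compound 1 `CN(C)CCN1CCN(CC(=O)Nc2ccc(-c3nc4cc(Cl)ccc4o3)cc2)CC1`: 28700 nM
- compound 2 `Cc1ccc2oc(-c3ccc(NC(=O)CN4CCN(CCN(C)C)CC4)cc3)nc2c1`: 28900 nM
- compound 3 `Cc1cc(-c2nc3cc(Cl)ccc3o2)ccc1NC(=O)CCl`: 8640 nM

Compound 4 `Cc1ccc2oc(-c3ccc(NC(=O)CCl)c(C)c3)nc2c1` has not been measured in this assay yet.

Compound 1 and compound 2 differ by methyl in place of chloro on an aromatic carbon; the step was a 1.0-fold higher number from compound 1 to compound 2 (0.00 log units; within the scatter). Their two values therefore give no order between them. Compound 3 sits below both of them in this assay, and that gap lies beyond the scatter. How the core of compound 3 differs from the core of compound 1 is not broken down here.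

Compound 4 differs from compound 3 by methyl in place of chloro on an aromatic carbon. This is the same change as that between compound 1 and compound 2, at a place described in the same words. On that one precedent, the step from compound 3 to compound 4 in this assay is expected to be flat, about a 1.1-fold higher number from compound 3 to compound 4 (0.04 log units; within the scatter), because the earlier change gave a 1.0-fold higher number from compound 1 to compound 2 (0.00 log units; within the scatter). Compound 4 is therefore estimated at 9500 nM in this assay. Among the compounds with values here, the range for compound 4 is expected to run from 4500 nM to 20000 nM; only one measured pair carries this change, so the range is kept wide.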

Compound 4, half-maximal inhibitory concentration: 6790 nM
Compound 4: the middle estimate sits 1.4-fold (0.15 log units) above what was measured, within the range that was stated.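

In this assay the exchange of chloro for methyl gives a 1.3-fold lower number from compound 3 to compound 4 (0.10 log units; within the scatter), so the values set no order between these two compounds. Set beside the earlier case, the change reads the same on both cores: the same change on two cores in this assay, a 1.0-fold higher number (0.00 log units; within the scatter) from compound 1 to compound 2 and a 1.3-fold lower number (0.10 log units; within the scatter) from compound 3 to compound 4, 1.3-fold (0.11 log units) apart, within the scatter of two such steps. Across these two pairs the exchange therefore carries from one core to the other as a flat step, but two pairs with flat steps make no rule for other cores, and they do not show why the number stays level or whether the same would hold in another assay.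

Open, from the compounds shown here alone, is whether a group other than chloro or methyl at this place, such as methoxy, trifluoromethyl or an amine, would move the number in this assay. Also open is whether the exchange stays flat on a core that carries a carboxylic acid or a longer chain on the amide in place of the side chains shown here.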